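The compounds below may be only part of what the source reports. "The series", "measured", "known", "first", "only" and "open" are said of these compounds alone.

Working notes on the series. Among the measured compounds shown here, in an assay on HEK293 cells for antagonist activity at Nicotinic acetylcholine receptor alpha-4/beta-2 (Mus musculus), read by FLIPR, using a membrane potential dye (on this read-out higher numbers stand for weaker inhibition and lower numbers for stronger inhibition), compound 1 `CO[C@H]1CC=C2CCN(C)[C@H]2C1` gives 30000 nM, the only number so far. Compound 2 `CN1CC[C@@H]2CC[C@H](O)C[C@@H]21` reaches only a limit of this assay, > 300000 nM. Compound 3 `O[C@H]1CC[C@H]2CCN[C@H]2C1` likewise reaches only a limit, > 100000 nM. Compound 2 sits at the limit of > 300000 nM in this assay, at which 1 of the 3 values shown sits. Compound 3 sits at the limit of > 100000 nM in this assay, at which 1 of the 3 values shown sits. The difference between the cores of compound 1 and compound 2 is not broken down here. From compound 2 to compound 3 the change is hydrogen in place of methyl on an amine nitrogen in a ring, and its step is a step that the two limits leave unreadable from compound 2 to compound 3. Compound 4 `CO[C@H]1CC=C2CCN[C@H]2C1` awaits measurement; its change from compound 1 is hydrogen in place of methyl on an amine nitrogen in a ring, the same kind of change, though the place is told without "two ring bonds from the ring atom that bears a fused ring". With the measured step of this kind unreadable, the expectation rests on compound 1 alone at 30000 nM and is wide. Compound 4 is expected at 60000 nM, between 15000 nM and 300000 nM, an expected step of a 2.0-fold higher number from compound 1 to compound 4 (0.30 log units; within the scatter) in this assay.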

Compound 4, half-maximal inhibitory concentration: 100000 nM
Compound 4: middle estimate off by 1.7-fold (0.22 log units), on the low side, within the range that was stated.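

In this assay, on the core of compound 1, hydrogen in place of methyl on an amine nitrogen in a ring gives a 3.3-fold higher number from compound 1 to compound 4 (0.52 log units; beyond the scatter) and so weakens inhibition modestly. The same change on the core of compound 2 cannot be read, so this single step shows neither that the change carries from one core to another nor that it fails to. Nothing measured here gives a cause for the step.

An ethyl group or a longer chain on the ring nitrogen is absent from the compounds shown, which leaves open how the read-out responds to anything beyond methyl and hydrogen there. Also open, going by these compounds, is the size of the change on the core of compound 2.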